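From a Ring to an Open Chain on Compound 2

The compounds below may be only part of what the source reports. "The series", "measured", "known", "first", "only" and "open" are said of these compounds alone.

Of the compounds shown here, three have been measured in a functional assay with Mus musculus as the target; a lower number here means that less compound is needed, a higher number that more compound is needed for the effect. Compound 1 `CCCn1c(=O)n(C2OC(COP(=O)(O)O)[C@@H](O)[C@H]2O)c2nc(N)nc(O)c21` gives 82 uM, compound 2 `C=CCn1c(=O)n([C@H]2CO[C@@H](CO)C2)c2nc(N)nc(O)c21` gives 272 uM, and compound 3 `CCOC(=O)Cn1c(=O)n(C2OC(CO)[C@@H](O)[C@H]2O)c2nc(N)nc(O)c21` gives 630 uM. Compound 2 therefore holds the middle place: it needs more compound than compound 1 and less than compound 3, and both gaps lie beyond the scatter of repeated measurements.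

Compound 4 `C=CCn1c(=O)n(CCCCO)c2nc(N)nc(O)c21` has not yet been measured. It keeps the shared core and the allyl group of compound 2, but a 4-hydroxybutyl chain replaces the ring-bearing group on an aromatic nitrogen: a group of 5 heavy atoms (4 carbon, 1 oxygen; no ring) in place of a group of 7 heavy atoms (5 carbon, 2 oxygen; one five-membered non-aromatic ring with 1 hetero atom), on an aromatic nitrogen.

Going by the values given here, no two measured compounds differ in only one place, so nothing here shows directly what such a change does. The best anchor is compound 2 at 272 uM. The estimated change, a 1.1-fold higher number from compound 2 to compound 4 (0.04 log units; within the scatter), is expected to stay within the scatter, with no firm direction. In this assay the estimate for compound 4 is 300 uM, with an expected range of 100 uM to 900 uM.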

Compound 4, concentration for half-maximal effect: 52 uM
The estimate for compound 4 lay 5.8-fold (0.76 log units) above the measured number; the whole stated range lies above it.
By their numbers in this assay, from the lowest: compounds 4 and 1 (each within the scatter of the next); then compound 2; then compound 3.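

In this assay, going by these compounds alone, putting a 4-hydroxybutyl chain in place of the ring-bearing group on the aromatic nitrogen gives a 5.2-fold lower number from compound 2 to compound 4 (0.72 log units; beyond the scatter), the first comparison here in which only one place differs. Within the data shown here, it shows that what sits on this nitrogen matters to the number, and that the five-membered non-aromatic ring with its 2 defined stereocentres is not required for the effect, as an open chain with no ring needs less compound. Nothing available says what lies behind this step.

The compounds shown leave open whether the chain length or the absence of the ring accounts for the step, as neither a propyl nor a hexyl chain with an end hydroxyl stands beside it. They also leave open what the end hydroxyl contributes, which a plain butyl chain or a 4-aminobutyl chain at this place would test.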